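Methyl on the piperidine ring of compound 2

The source may report more compounds than this note shows. Statements on the series, on what has been measured and on what is new or still open speak of the compounds shown alone.

Compound 2 `Cc1cc(Cl)cc(-c2ccnc3cc(CN4C(=O)CCC4=O)sc23)c1OC1CCNCC1` gives the highest of the two numbers measured in an assay on isolated protein for inhibition of ubiquitin carboxyl-terminal hydrolase 7 (Homo sapiens), read by fluorescence, with stated times of 30 min and 1 h (a lower number here means a stronger inhibitor, a higher number a weaker inhibitor), at 8 nM. Compound 1 `Cc1cc(Cl)cc(-c2ccnc3cc(CN4C(=O)C5C(C4=O)C5(C)C)sc23)c1O[C@@H]1CCNC[C@@H]1C` gives 0.18 nM in this assay, a lower number beyond the scatter, though the two differ in more than one place. Compound 3 `Cc1cc(Cl)cc(-c2ccnc3cc(CN4C(=O)CCC4=O)sc23)c1O[C@@H]1CCNC[C@@H]1C` is not yet measured. It differs from compound 2 by methyl in place of hydrogen on a saturated ring carbon. Going by the values given here, no single step of this kind is measured here, so only a direction is expected: a lower number, since compound 1 with 0.18 nM carries the same methyl. Compound 3 is estimated at 2 nM, range 0.5 nM to 8 nM. The step expected is a 4.0-fold lower number from compound 2 to compound 3 (0.60 log units; beyond the scatter).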

Compound 3, half-maximal inhibitory concentration: 2.1 nM
Beside the measured number, compound 3's estimate is 1.1-fold (0.02 log units) below it, and the stated range covers the measured number.
By their numbers in this assay, from the lowest: compound 1; then compound 3; then compound 2.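

Methyl in place of hydrogen on this saturated ring carbon, two ring bonds from the ring nitrogen, now stands as a single step in this assay: a 3.8-fold lower number from compound 2 to compound 3 (0.58 log units; beyond the scatter). With that methyl held constant, the group on the saturated chain carbon gives a separate step, a 12-fold higher number from compound 1 to compound 3 (1.07 log units; beyond the scatter), so the gap between compound 1 and compound 2 comes from changes in both places. Nothing at hand gives a cause for either step.

Open, from the compounds shown here alone, are an ethyl or a fluorine on this ring carbon and the opposite configuration of the methyl. Also open, going by these compounds, is the size of the methyl step when the group of compound 1 stands on the chain carbon.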